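This account rests on a few compounds, and the source may have more. Where it says the series, first, only, none or still open, it means among the compounds named here.

Measured so far:
- compound 1, `Cc1ccc(-n2ccnc2SCC(=O)Nc2ccccc2[N+](=O)[O-])cc1`, gives 131000 nM in an ADME assay on MT4 cells (Homo sapiens) for cytotoxicity, read by MTT assay; a higher number here means that more compound is tolerated, a lower number that less compound is tolerated
- compound 2, `COc1ccc(-n2ccnc2SCC(=O)Nc2ccccc2F)cc1`, gives >= 41900 nM in this assay

The value for compound 2 is a limit of the assay and not a number, so compound 2 stands only at that boundary and its true position is not pinned down; this is the limit of >= 41900 nM in this assay, at which 1 of the 2 values shown sits. Compound 3, `COc1ccc(-n2ccnc2SCC(=O)Nc2ccccc2[N+](=O)[O-])cc1`, has not yet been measured in this assay. The change from compound 2 to compound 3 is nitro in place of fluoro on an aromatic carbon, in words nitro in place of fluoro on an aromatic carbon. Among the measured compounds shown here, since compound 2 is a limit, no measured step is available to judge against. Compound 1, which carries the same nitro group, gives 131000 nM, and compound 3 is expected to land near it, at 110000 nM with a range from 40000 nM to 300000 nM. The estimated step that the limit leaves unreadable from compound 2 to compound 3 cannot be called larger than the scatter, as compound 2 is only a limit.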

Compound 3, half-maximal cytotoxic concentration: 161000 nM
The estimate for compound 3 lay 1.5-fold (0.17 log units) below the measured number; measured number inside the range.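

With the nitro group held constant, methoxy in place of methyl on an aromatic carbon gives a 1.2-fold higher number from compound 1 to compound 3 (0.09 log units; within the scatter), so these two compounds cannot be told apart in this assay. The value of compound 2, >= 41900 nM, is a limit of the assay and not a number. The effect of nitro in place of fluoro therefore cannot be read, because compound 2 stands only at a boundary: the limit of >= 41900 nM in this assay, at which 1 of the 3 values shown sits.

On these data alone, it remains open whether the 2-fluorophenyl to 2-nitrophenyl change alters the tolerated concentration at all, or whether the two groups would sit within the usual scatter of each other. Also open, as far as these compounds go, is how an amine or a carboxylic acid would behave on that aromatic carbon, and whether a longer chain in place of the methoxy group would leave the number where it stands.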